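The compounds below may be only part of what the source reports. "The series", "measured", "known", "first", "only" and "open" are said of these compounds alone.

Of the compounds shown here, three have been measured in an assay on HEK293 cells for displacement of a labelled ligand from Melanocortin receptor 4 (Homo sapiens); a higher number here means a weaker inhibitor, a lower number a stronger inhibitor. Compound 1 `CC[C@H](C)C(N)c1cc(C(F)(F)F)ccc1N1CCN(C(=O)CCc2ccc(Cl)cc2Cl)CC1` gives 75 nM. Compound 2 `CCC(C)CN[C@H](c1cc(C(F)(F)F)ccc1N1CCN(C(=O)CCc2ccc(Cl)cc2Cl)CC1)C(C)CC` gives 2800 nM, and compound 3 `CCC(C)[C@H](NC(=O)OC)c1cc(C(F)(F)F)ccc1N1CCN(C(=O)CCc2ccc(Cl)cc2Cl)CC1` gives 2400 nM. Among these three numbers, compound 3 stands second highest: its number and that of compound 2 lie within the usual scatter of each other, while compound 1 sits far lower. The two steps away from compound 1 show how wide that gap is: a 37-fold higher number from compound 1 to compound 2 (1.57 log units; beyond the scatter) and a 32-fold higher number from compound 1 to compound 3 (1.51 log units; beyond the scatter). The step of a 1.2-fold lower number from compound 2 to compound 3 (0.07 log units; within the scatter) shows that exchanging one group for the other on the amine nitrogen made no difference beyond the scatter.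

Compound 4 `CCC(C)[C@H](NC(=O)CN)c1cc(C(F)(F)F)ccc1N1CCN(C(=O)CCc2ccc(Cl)cc2Cl)CC1` is the next to be measured. Relative to compound 3, the change is aminomethyl in place of methoxy on a carbonyl carbon. For the measured compounds named here, no measured step covers this particular exchange. The steps of a 32-fold higher number from compound 1 to compound 3 (1.51 log units; beyond the scatter) and a 37-fold higher number from compound 1 to compound 2 (1.57 log units; beyond the scatter) both show that adding a group to the nitrogen of the 1-amino-2-methylbutyl group cost a great deal, whereas a 1.2-fold lower number from compound 2 to compound 3 (0.07 log units; within the scatter) shows that two different groups there gave results within the scatter. Compound 4 keeps a carbonyl on that nitrogen. Only a small step is expected: a 1.6-fold lower number from compound 3 to compound 4 (0.20 log units; within the scatter). Compound 4 is estimated at 1500 nM in this assay, with a range from 400 nM to 6000 nM.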

Compound 4, inhibition constant: 18 nM
For compound 4 the middle estimate is 83-fold (1.92 log units) above the measured one, outside the stated range (below it).
By their numbers in this assay, from the lowest: compound 4; then compound 1; then compounds 3 and 2 (each within the scatter of the next).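

In this assay, aminomethyl in place of methoxy on a carbonyl carbon gives a 130-fold lower number from compound 3 to compound 4 (2.12 log units; beyond the scatter) and makes compound 4 the strongest of the four, so the small group on this carbonyl strongly affects the result, even though each group counts only 2 heavy atoms. Compounds 2 and 3 had suggested that a group on the amine nitrogen of compound 1 is costly, but compound 4 goes against this: (aminomethyl)carbonyl on that nitrogen gives a 4.2-fold lower number from compound 1 to compound 4 (0.62 log units; beyond the scatter) and, in place of 2-methylbutyl, gives a 160-fold lower number from compound 2 to compound 4 (2.19 log units; beyond the scatter) as well. No evidence is available to explain these steps.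

The compounds shown do not separate the contribution of the amine in the aminomethyl group from that of its carbon. A plain methyl, a dimethylamino group or a longer chain ending in an amine on this carbonyl could test this.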